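The compounds below may be only part of what the source reports. "The series", "measured", "known", "first", "only" and "open" are said of these compounds alone.

Measured compounds:
- compound 1, `Cc1cccc(/C(=N/O)Nc2ccc([N+](=O)[O-])c3nonc23)c1`: 163 nM
- compound 2, `O=[N+]([O-])c1ccc(N/C(=N\O)c2cccc(F)c2)c2nonc12`: 75 nM
- compound 3, `Cc1ccc(/C(=N/O)Nc2ccc([N+](=O)[O-])c3nonc23)cc1`: 204 nM

All three numbers come from an assay on isolated protein for inhibition of Indoleamine 2,3-dioxygenase 1 (Homo sapiens), read by spectrophotometry, with a stated time of 1 h; on this read-out lower numbers stand for stronger inhibition and higher numbers for weaker inhibition. Compound 1 and compound 3 share every atom and differ only in how the atoms are joined: 4-methylphenyl in place of 3-methylphenyl on a carbon with a double bond to nitrogen. Between them the step is a 1.3-fold higher number from compound 1 to compound 3 (0.10 log units; within the scatter), so the two cannot be ordered. Compound 2 stands apart from both, with a 2.2-fold lower number from compound 1 to compound 2 (0.34 log units; beyond the scatter) and a 2.7-fold higher number from compound 2 to compound 3 (0.43 log units; beyond the scatter).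

The change from compound 1 to compound 2 is fluoro in place of methyl on an aromatic carbon. The same kind of change, not the same one, leads from compound 3 to compound 4, `O=[N+]([O-])c1ccc(N/C(=N\O)c2ccc(F)cc2)c2nonc12`: fluoro in place of methyl on an aromatic carbon. The two places are not identical: in the pair compound 1 to compound 2 the change sits meta to a large group, in the pair compound 3 to compound 4 it sits para to a large group. Among the compounds here the change occurs twice in all, so only the one measured step stands as a guide.

For compound 4 in this assay a step of about the same size is expected as the earlier one, resting on compound 1 to compound 2 with a 2.2-fold lower number from compound 1 to compound 2 (0.34 log units; beyond the scatter) and on the near-equal values of compound 1 and compound 3; the expected step is a 2.0-fold lower number from compound 3 to compound 4 (0.31 log units; beyond the scatter). Compound 4 is estimated at 100 nM, with a range from 50 nM to 250 nM to allow for the different place of the change.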

Compound 4, half-maximal inhibitory concentration: 100 nM
Compound 4: the middle estimate sits on the measured number at the digits printed; low and high end bracket the measured number.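

In this assay, fluoro in place of methyl on an aromatic carbon gives a 2.0-fold lower number from compound 3 to compound 4 (0.31 log units; beyond the scatter), and this step repeats the earlier one in size: the same change on two cores in this assay, a 2.2-fold lower number (0.34 log units; beyond the scatter) from compound 1 to compound 2 and a 2.0-fold lower number (0.31 log units; beyond the scatter) from compound 3 to compound 4, 1.1-fold (0.03 log units) apart, within the scatter of two such steps

The position of the group shifts little in the fluoro pair, with a 1.3-fold higher number from compound 2 to compound 4 (0.12 log units; within the scatter), and the listed step to the 3-methylphenyl compound is a 1.6-fold lower number from compound 1 to compound 4 (0.21 log units; within the scatter); both lie within the scatter, so compound 4 cannot be ordered against compound 2 or compound 1. This supports carrying the change between the 3-methylphenyl and 4-methylphenyl compounds, but it rests on two pairs that share the same remaining structure and involve only methyl and fluoro, so it does not show that the step would hold on a different core or for any other group, and it gives no cause for the step.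

As far as these compounds go, whether chloro, methoxy, an amine or a carboxylic acid on the phenyl ring would follow the same course stays open, as does the effect of any change to the shared core. From the compounds shown here alone, all of this comes from this assay alone, so how the compounds behave in cells also remains open.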